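The source may hold more compounds than are shown below. What is called first, only, known or untested is meant among the compounds shown, and "the series" means these compounds.

Measured so far in a functional assay on J774.A1 cells (Mus musculus) for inhibition, read by Griess assay, with stated times of 1 h and 24 h (on this read-out lower numbers stand for stronger inhibition and higher numbers for weaker inhibition), for this series:

- compound 1 `O=C1CC(c2ccccc2OCc2ccc(F)cc2)Oc2ccccc21` gives 25500 nM
- compound 2 `CC(C)COc1ccccc1C1CC(=O)c2ccccc2O1` gives 33200 nM
- compound 3 `CCCCCOc1ccccc1C1CC(=O)c2ccccc2O1` gives 39300 nM

Compound 2 (33200 nM) stands level with compound 1 and compound 3 within the scatter, so the three cannot be ranked.

Compound 4 `CC(C)=CCOc1ccccc1C1CC(=O)c2ccccc2O1` differs from compound 2 in one place (2-methylprop-1-en-1-yl in place of isopropyl on a saturated chain carbon bound to an oxygen on an aromatic ring) with 2-methylprop-1-en-1-yl in place of isopropyl on a saturated chain carbon bound to an oxygen on an aromatic ring.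

Three measured steps at this same place bear on the change. They are (a 1.2-fold higher number from compound 2 to compound 3 (0.07 log units; within the scatter)) with butyl in place of isopropyl, (a 1.3-fold higher number from compound 1 to compound 2 (0.11 log units; within the scatter)) with isopropyl in place of 4-fluorophenyl, and (a 1.5-fold higher number from compound 1 to compound 3 (0.19 log units; within the scatter)) with butyl in place of 4-fluorophenyl. Going by these compounds, none of the three measured compounds has the double bond of the entering group, so that feature remains untested.

Taking compound 2 (33200 nM) as the starting point, no step beyond the scatter is expected in this assay for compound 4. The expected size is a 1.0-fold lower number from compound 2 to compound 4 (0.02 log units; within the scatter) on this reasoning. Compound 4 is estimated at 32000 nM with an expected range of 15000 nM to 65000 nM in this test.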

Compound 4, half-maximal inhibitory concentration: 34300 nM
Compound 4: the middle estimate sits 1.1-fold (0.03 log units) below what was measured; low and high end bracket the measured number.
By their numbers in this assay, from the lowest: compounds 1, 2, 4 and 3 (each within the scatter of the next).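

In this assay, for the compounds shown here, the double bond of 2-methylprop-1-en-1-yl, the one feature the earlier compounds lacked, brings no step beyond the scatter: the change from isopropyl reads (a 1.0-fold higher number from compound 2 to compound 4 (0.01 log units; within the scatter)), the change from butyl reads (a 1.1-fold lower number from compound 3 to compound 4 (0.06 log units; within the scatter)), and the change from 4-fluorophenyl reads (a 1.3-fold higher number from compound 1 to compound 4 (0.13 log units; within the scatter)). On a saturated chain carbon bound to an oxygen on an aromatic ring, four quite different groups (branched, straight, unsaturated and aromatic) therefore cannot be told apart, and the four compounds cannot be ranked. No measurement at hand speaks to why these groups read alike.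

Going by these compounds, it stays open whether an amine, a carboxylic acid or a much longer chain at this place would move the number beyond the scatter. On these data alone, all four compounds share one core, so the effect of changes elsewhere on it also remains open.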